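The source may hold more compounds than are shown below. What is called first, only, known or untested is meant among the compounds shown, and "the series" means these compounds.

Measured so far in a functional assay on K562 cells (Homo sapiens) for cytotoxicity, read by sulforhodamine B assay; a lower number here means a stronger inhibitor of growth, a higher number a weaker inhibitor of growth:
compound 1 `CC1=CC[C@@H]([C@@](C)(O)CCCC(C)(C)NC(=S)N/N=C\c2ccc(C)cc2)CC1`, 140 nM;
compound 2 `COc1ccc(/C=N\NC(=S)NC(C)(C)CCC[C@](C)(O)[C@@H]2CC=C(C)CC2)cc1`, 220 nM.

Within the data shown here, compound 2 stands alongside compound 1 on these two numbers: the only step between them, a 1.6-fold higher number from compound 1 to compound 2 (0.20 log units; within the scatter), lies within the scatter, so the two cannot be told apart in this assay.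

Compound 3 `CC1=CC[C@@H]([C@@](C)(O)CCCC(C)(C)NC(=S)N/N=C\c2ccc(O)cc2)CC1` differs from compound 2 by hydrogen in place of methyl on an oxygen on an aromatic ring; cut one bond further out this reads methoxy to hydroxy, 4-methoxyphenyl to 4-hydroxyphenyl. Among the measured compounds shown here, the one measured step that bears on this change is the swap at the same aromatic carbon, a 1.6-fold higher number from compound 1 to compound 2 (0.20 log units; within the scatter), which did not move the number beyond the scatter. With nothing else to go on, the account expects no step beyond the scatter here either, and estimates the step from compound 2 as a 1.1-fold higher number from compound 2 to compound 3 (0.06 log units; within the scatter). Compound 3 is therefore expected to give about 250 nM in this assay, within a range of 90 nM to 700 nM.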

Compound 3, concentration for 50% growth inhibition: 600 nM
Compound 3: middle estimate off by 2.4-fold (0.38 log units), on the low side; the measured number falls inside the stated range.
By their numbers in this assay, from the lowest: compounds 1 and 2 (each within the scatter of the next); then compound 3.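

In this assay this aromatic carbon no longer looks indifferent to what it carries: hydrogen in place of methyl on the oxygen gives a 2.7-fold higher number from compound 2 to compound 3 (0.44 log units; beyond the scatter) and hydroxy in place of methyl on the aromatic carbon gives a 4.3-fold higher number from compound 1 to compound 3 (0.63 log units; beyond the scatter). The step between compound 1 and compound 2 stayed within the scatter. Among these three compounds, only the 4-hydroxyphenyl compound stands apart, as the weaker inhibitor of growth, and the oxygen alone does not go with the higher number, as the methoxy of compound 2 also places an oxygen on that ring. Nothing at hand accounts for this step.

The compounds shown leave open how an amine or a carboxylic acid on this carbon, or an ethoxy group with its longer chain on the oxygen, would read. They also leave open whether the same step would hold on a changed core.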